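The compounds below may be only part of what the source reports. "The series", "measured", "known", "first", "only" and "open" are said of these compounds alone.

Compound 1 `COc1ccccc1/C=C/C(=O)OC/C=C/c1cc(OC)c(OC)cc1OC` gives 240 mg/kg
Compound 2 `COc1cc(OC)c(OC)cc1/C=C/COC(=O)/C=C/c1ccc(Br)cc1` gives 193 mg/kg
Compound 3 `COc1cc(OC)c(OC)cc1/C=C/COC(=O)/C=C/c1cccc(Br)c1` gives > 200 mg/kg
Compound 4 `COc1cc(OC)c(OC)cc1/C=C/COC(=O)/C=C/c1ccccc1Cl` is not yet measured

All of these values come from a functional assay on the whole organism (strain Kunming) with Mus musculus as the target, with a stated time of 0.5 h; on this read-out lower numbers stand for an effect already at smaller amounts and higher numbers for an effect only at larger amounts of compound. Compound 3 gives > 200 mg/kg, which is a limit of the assay and not a number. Its exact standing is therefore unknown.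

The next step is a swap of one aromatic group, described as 2-chlorophenyl in place of 3-bromophenyl on a double-bonded chain carbon bound to a double-bonded chain carbon. A 2-chlorophenyl takes the place of the 3-bromophenyl on a double-bonded chain carbon bound to a double-bonded chain carbon.

Earlier swaps at this same place are the best guide. The first is a 1.2-fold lower number from compound 1 to compound 2 (0.09 log units; within the scatter), which lies within the scatter. The second is an at least 1.0-fold higher number from compound 2 to compound 3 (0.01 log units; that floor lies within the scatter), and its floor also lies within the scatter. The third is a step that the limit leaves unreadable from compound 1 to compound 3, so it gives no usable size.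

None of these swaps shows a step beyond the scatter, so none is expected here in this assay. The expected step is a step that the limit leaves unreadable from compound 3 to compound 4. The estimate for compound 4 is 210 mg/kg, with an expected range from 120 mg/kg to 360 mg/kg.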

Compound 4, dose for half-maximal effect: 150 mg/kg
For compound 4 the middle estimate is 1.4-fold (0.15 log units) above the measured one; the measured number falls inside the stated range.
By their numbers in this assay, from the lowest: compounds 4, 2 and 1 (each within the scatter of the next).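

In this assay, compound 4 puts a chlorine-bearing ring, 2-chlorophenyl, at this place and gives a readable number, which 3-bromophenyl in compound 3 did not. The change stays small against the other two compounds, with a 1.3-fold lower number from compound 2 to compound 4 (0.11 log units; within the scatter) and a 1.6-fold lower number from compound 1 to compound 4 (0.20 log units; within the scatter), so 2-methoxyphenyl, 4-bromophenyl and 2-chlorophenyl cannot be told apart in this assay. Against compound 3 there is only a floor, an at least 1.3-fold lower number from compound 3 to compound 4 (0.12 log units; that floor lies within the scatter), and the true size of that step stays unknown, as the value of compound 3 is a limit of the assay and not a number: the limit of > 200 mg/kg in this assay, at which 1 of the 4 values shown sits.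

On these data alone, what stays open is whether any group at this place can produce a step beyond the scatter. An unsubstituted phenyl, or a phenyl carrying an amine or a carboxylic acid, could test this.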